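The compounds below may be only part of what the source reports. "The series", "measured", "known", "first", "only" and "open" are said of these compounds alone.

Measured compounds:
compound 1, `O=C(O)CCC/C=C\C[C@H]1[C@@H]2CCC(C2)[C@@H]1NS(=O)(=O)c1cccc2ccccc12`: 2.7 nM
compound 2, `Cc1ccccc1S(=O)(=O)N[C@H]1C2CC[C@H](C2)[C@@H]1C/C=C\CCCC(=O)O`: 3.7 nM
compound 3, `O=C(O)CCC/C=C\C[C@H]1[C@@H]2CCC(C2)[C@@H]1NS(=O)(=O)CCCc1ccccc1`: 10.9 nM

In a functional assay (thoracic aorta) for inhibition, with Rattus norvegicus as the target (a higher number here means a weaker inhibitor, a lower number a stronger inhibitor), compound 3 gives the highest of the three numbers; the nearest is compound 2 at 3.7 nM and the furthest compound 1 at 2.7 nM. Compound 4, `O=C(O)CCC/C=C\C[C@H]1[C@@H]2CCC(C2)[C@@H]1NS(=O)(=O)Cc1ccccc1`, is not yet measured in this assay. It differs from compound 3 by phenyl in place of phenethyl on a saturated chain carbon bound to a sulfonyl sulfur, so the 3-phenylpropyl of compound 3 becomes benzyl.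

For the measured compounds named here, two measured steps bear on this. The step of a 4.0-fold higher number from compound 1 to compound 3 (0.61 log units; beyond the scatter) and the step of a 2.9-fold higher number from compound 2 to compound 3 (0.47 log units; beyond the scatter) both show that moving from an aromatic ring directly on the sulfonyl sulfur to the three-carbon-linked 3-phenylpropyl costs a modest amount. Benzyl shortens that link, leaving the ring closer to the sulfonyl sulfur than in compound 3, though not directly on it as in compound 1 and compound 2. A partial recovery is therefore expected: compound 4 is estimated to give a modestly lower number in this assay, a step of a 1.8-fold lower number from compound 3 to compound 4 (0.26 log units; within the scatter), placing it at about 6 nM (range 3 nM to 14 nM).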

Compound 4, half-maximal inhibitory concentration: 111 nM
The estimate for compound 4 lay 19-fold (1.27 log units) below the measured number; measured number above the stated range.
By their numbers in this assay, from the lowest: compounds 1 and 2 (each within the scatter of the next); then compound 3; then compound 4.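

In this assay the link on the sulfonyl sulfur does not act as a simple gradient: shortening 3-phenylpropyl to benzyl gives a 10-fold higher number from compound 3 to compound 4 (1.01 log units; beyond the scatter), so the number does not fall as the ring comes closer to the sulfur. Benzyl is the weakest of the four groups, with a 30-fold higher number from compound 2 to compound 4 (1.48 log units; beyond the scatter) and a 41-fold higher number from compound 1 to compound 4 (1.61 log units; beyond the scatter), so a single saturated carbon on the sulfur costs far more than the longer 3-phenylpropyl does, and the directly attached rings of compound 1 and compound 2 remain the strongest. Nothing measured here accounts for this loss at benzyl.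

Still open, as far as these compounds go, is whether phenethyl on the sulfonyl sulfur would fall nearer benzyl or 3-phenylpropyl, and whether a chain longer than 3-phenylpropyl would continue the trend. Also open, from the compounds shown here alone, is whether a methyl group on the benzyl ring, as in 2-methylbenzyl, would recover any of the loss.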